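Methoxy to Hydroxy on the Shared Core: What to Expect

The source may report more compounds than this note shows. Statements on the series, on what has been measured and on what is new or still open speak of the compounds shown alone.

Compound 1 `COc1cc(-c2nn(-c3ccc(NC(=O)c4ccc(Cl)c(Cl)c4)cc3)cc2-c2ccncc2)ccc1Cl`: 13000 nM
Compound 2 `COc1cc(-c2nn(-c3ccc(NC(=O)c4ccc(Cl)c(C(F)(F)F)c4)cc3)cc2-c2ccncc2)ccc1Cl`: 9800 nM

Of the compounds shown here, two have been measured in a functional assay on A375P cells (Homo sapiens) for antiproliferative activity, read by MTT assay, with a stated time of 48 h; on this read-out higher numbers stand for weaker inhibition and lower numbers for stronger inhibition. Compound 1 gives 13000 nM, and compound 2 gives 9800 nM. The single measured step, a 1.3-fold lower number from compound 1 to compound 2 (0.12 log units; within the scatter), is within the scatter, so compound 2 carries the lower of the two numbers shown without being separated from compound 1.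

Compound 3 `O=C(Nc1ccc(-n2cc(-c3ccncc3)c(-c3ccc(Cl)c(O)c3)n2)cc1)c1ccc(Cl)c(C(F)(F)F)c1` differs from compound 2 in one place: hydrogen in place of methyl on an oxygen on an aromatic ring. Among the measured compounds shown here, no measured step touches the oxygen on the aromatic ring; the only step available, a 1.3-fold lower number from compound 1 to compound 2 (0.12 log units; within the scatter), concerns the trifluoromethyl and chloro on the amide side and offers no guide to this change. With nothing to anchor a direction, compound 3 is expected to sit close to compound 2, the estimated step being a 1.2-fold lower number from compound 2 to compound 3 (0.09 log units; within the scatter), which is no change beyond the scatter. The estimate for compound 3 is 8000 nM, with a range from 3000 nM to 25000 nM.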

Compound 3, half-maximal inhibitory concentration: 6800 nM
Compound 3: middle estimate off by 1.2-fold (0.07 log units), on the high side, within the range that was stated.
By their numbers in this assay, from the lowest: compounds 3, 2 and 1 (each within the scatter of the next).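

Among the compounds shown here, the earlier compounds differed only on the amide side, so this is the first reading at the oxygen on the aromatic ring: in this assay, going from methoxy to hydroxy gives a 1.4-fold lower number from compound 2 to compound 3 (0.16 log units; within the scatter). On this pair, then, the methyl on that oxygen can be exchanged for hydrogen without the two compounds being separated on this read-out. No supporting measurement is available to explain this result.

Going by these compounds, it remains open whether a different group in place of the hydroxy, such as an amine or a carboxylic acid, would separate from compound 3. On these data alone, it also remains open whether methoxy and hydroxy would stay this close with the chloro of compound 1 on the amide side instead of the trifluoromethyl.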